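A few compounds are considered here, and "the series" means these few. Any claim that something is new, unique, unknown or untested is made for them only; others in the source may bear on it.

Measured compounds in this series:

compound 1 `Cc1nc(N)c2nc(O)n(Cc3ccccc3)c2n1` — 1 uM
compound 2 `Nc1ncnc2c1nc(O)n2C1CCCC1` — > 10 uM
compound 3 `Cc1nc2c(N)ncnc2n1Cc1ccccc1` — > 10 uM

For the measured compounds named here, compound 1 is the only member with a number in a functional assay (spleen, spleen) for activation, with Mus musculus as the target; on this read-out lower numbers stand for an effect already at smaller amounts and higher numbers for an effect only at larger amounts of compound. Compound 2 gives only the limit > 10 uM, which is a limit of the assay and not a number. Compound 3 likewise reaches only the limit > 10 uM. So in this assay compound 1 stands alone as the one compound with a measured concentration, and the rest of the set sits at the limit of > 10 uM in this assay, at which 2 of the 3 values shown sit. Going by the values given here, no pair among the measured compounds differs in a single place, so no step within the measured set can be sized.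

The next compound, compound 4 `CSc1nc(N)c2nc(O)n(Cc3ccccc3)c2n1`, differs from compound 1 in one place: methylsulfanyl in place of methyl on an aromatic carbon. The remainder of the shared core of compound 1, including the group on the ring nitrogen, is kept.

Compound 4 is expected to give a concentration in this assay similar to or somewhat smaller than compound 1, a step of a 2.0-fold lower number from compound 1 to compound 4 (0.30 log units; within the scatter) that may fall within the usual scatter or go a little beyond it toward smaller amounts. The estimate for compound 4 is 0.5 uM, with a range from 0.1 uM to 3 uM.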

Compound 4, minimum effective concentration: 0.1 uM
Compound 4: middle estimate off by 5.0-fold (0.70 log units), on the high side; the measured number falls inside the stated range.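

In this assay, the aromatic carbon between two ring nitrogen atoms proves sensitive to its substituent: methylsulfanyl in place of methyl gives a 10-fold lower number from compound 1 to compound 4 (1.00 log units; beyond the scatter). For the compounds shown here, this is the first step that can be sized, and with the rest of the shared core and the group on the ring nitrogen kept, it ties the lower number to this one place and shows that the position accepts a group carrying sulfur without loss in this assay. Compound 2 and compound 3 each differ from compound 4 in more than one place, so no step to them can be read, and each stays at a limit of the assay rather than a number: the limit of > 10 uM in this assay, at which 2 of the 4 values shown sit.

Only methyl and methylsulfanyl are compared at this position, which leaves open whether the lower number follows the sulfur atom or simply the longer substituent. On these data alone, a methoxy group, an ethylsulfanyl chain or an amine on the same carbon would bear on that question, and it also remains open whether the step holds with another group on the ring nitrogen.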